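The source may hold more compounds than are shown below. What is called first, only, known or untested is meant among the compounds shown, and "the series" means these compounds.

Compound 1 `O=C1/C(=C/c2ccc(F)cc2)CCCc2ccccc21` is the point of reference. In a functional assay on CCRF-CEM cells (Homo sapiens) for inhibition (a higher number here means a weaker inhibitor, a lower number a stronger inhibitor), compound 1 gives 20000 nM. Compound 2 `O=C1/C(=C/c2ccc(Cl)cc2)CCCc2ccccc21` differs from it by chloro in place of fluoro on an aromatic carbon, and in this assay compound 2 gives 15100 nM. The step is a 1.3-fold lower number from compound 1 to compound 2 (0.12 log units; within the scatter).

Compound 3 `O=C1CCCCC/C1=C\c1cccc(F)c1` carries a different core; how the two cores differ is not broken down here. In this assay compound 3 gives 224000 nM, the highest of the three numbers, beyond the scatter from both compound 1 and compound 2.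

Compound 4 `O=C1CCCCC/C1=C\c1cccc(Cl)c1` has not yet been measured. It differs from compound 3 by chloro in place of fluoro on an aromatic carbon. This is the same kind of change as that from compound 1 to compound 2, though not the same: in compound 2 the chloro sits para to a large group, in compound 4 meta to a group of 9 heavy atoms.

The step from compound 3 to compound 4 is expected to be small, a 1.3-fold lower number from compound 3 to compound 4 (0.12 log units; within the scatter), because a 1.3-fold lower number from compound 1 to compound 2 (0.12 log units; within the scatter) lay within the scatter. Compound 4 is therefore estimated at 170000 nM in this assay, with a range from 80000 nM to 400000 nM expected.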

Compound 4, half-maximal inhibitory concentration: 40500 nM
Compound 4: middle estimate off by 4.2-fold (0.62 log units), on the high side, and the stated range ends above it.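

In this assay, chloro in place of fluoro on an aromatic carbon gives a 5.5-fold lower number from compound 3 to compound 4 (0.74 log units; beyond the scatter), so on the core of compound 3 this change has a readable effect, whereas on the core of compound 1 it stayed within the scatter. The size of the step therefore does not carry over from one core to the other: the same change on two cores in this assay, a 1.3-fold lower number (0.12 log units; within the scatter) from compound 1 to compound 2 and a 5.5-fold lower number (0.74 log units; beyond the scatter) from compound 3 to compound 4, 4.2-fold (0.62 log units) apart, beyond the scatter of two such steps The two pairs differ in the core and also in where the halogen sits on the ring, so they cannot show which of the two sets the steps apart, and two pairs give no general rule for this series.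

The compounds shown leave open whether the same halogen swap, made at one ring place on both cores, would give steps of matching size. They also leave open how bromo, methyl, methoxy or an amine at that place would compare with chloro on the core of compound 3.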